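Notes on the series: from compound 3 to compound 4

A few compounds are considered here, and "the series" means these few. Any claim that something is new, unique, unknown or untested is made for them only; others in the source may bear on it.

Three compounds have numbers in a functional assay for positive allosteric modulation of GABA-B receptor (Homo sapiens), read by GTPgammaS binding; on this read-out higher numbers stand for an effect only at larger amounts of compound and lower numbers for an effect already at smaller amounts. Compound 1 `Cc1nc(N[C@@H]2C[C@H]3CC[C@@H]2C3)c2cc(-c3ccc(Cl)c(Cl)c3)ccc2n1` gives 419 nM, compound 2 `FC(F)(F)c1ccc(-c2ccc3nc(Cl)nc(N[C@@H]4C[C@H]5CC[C@@H]4C5)c3c2)cc1` gives 637 nM, and compound 3 `Clc1ccc(-c2ccc3nc(Cl)nc(N[C@@H]4C[C@H]5CC[C@@H]4C5)c3c2)cc1` gives 208 nM. Among the measured compounds shown here, the single measured step, a 3.1-fold lower number from compound 2 to compound 3 (0.49 log units; beyond the scatter), is the only change beyond the scatter; compound 3 carries the lowest number of the three, but its gap to compound 1 lies within the scatter. Compound 4 `Clc1nc(N[C@@H]2C[C@H]3CC[C@@H]2C3)c2cc(-c3ccc(Cl)c(Cl)c3)ccc2n1` differs from compound 3 by chloro in place of hydrogen on an aromatic carbon. For the measured compounds named here, no measured step covers this change directly. Compound 1 carries the same 3,4-dichlorophenyl and sits within the scatter of compound 3, so no step beyond the scatter is expected for compound 4 in this assay. For compound 4 the estimate is 250 nM, range 100 nM to 650 nM, expected as a 1.2-fold higher number from compound 3 to compound 4 (0.08 log units; within the scatter).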

Compound 4, half-maximal effective concentration: 341 nM
Compound 4: the middle estimate sits 1.4-fold (0.13 log units) below what was measured; measured number inside the range.
By their numbers in this assay, from the lowest: compounds 3, 4, 1 and 2 (each within the scatter of the next, the first and the last beyond it).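

In this assay, going from 4-chlorophenyl to 3,4-dichlorophenyl gives a 1.6-fold higher number from compound 3 to compound 4 (0.21 log units; within the scatter), so this position of the phenyl ring accepts a chloro with no step beyond the scatter. With the 3,4-dichlorophenyl held constant, chloro in place of methyl on an aromatic carbon of the shared core gives a 1.2-fold lower number from compound 1 to compound 4 (0.09 log units; within the scatter), which also stays within the scatter. No supporting evidence accompanies these readings.

Open, as far as these compounds go, is how a methoxy group, a nitrile or an amine at this phenyl position would read. Also open, from the compounds shown here alone, is how an amine or a longer chain would read in place of the chloro on the core.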